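Lengthening the Chain Between Ester Oxygen and Phenyl Ring

This account rests on a few compounds, and the source may have more. Where it says the series, first, only, none or still open, it means among the compounds named here.

Three compounds built on one shared core were measured in an assay on microsomes from intestine for inhibition of acyl-CoA:cholesterol acyltransferase (Oryctolagus cuniculus); on this read-out lower numbers stand for stronger inhibition and higher numbers for weaker inhibition. Compound 3 `CC(C)c1cccc(C(C)C)c1OC(=O)NC(=O)OCc1ccccc1` gives 77 nM, the lowest number of the three. Compound 1 `CC(C)c1cccc(C(C)C)c1OC(=O)NC(=O)OC(c1ccccc1)c1ccccc1` gives 350 nM, and compound 2 `COC(=O)C(OC(=O)NC(=O)Oc1c(C(C)C)cccc1C(C)C)c1ccccc1` gives 940 nM. The two measured steps leading to compound 3 both ran toward lower numbers: a 4.5-fold lower number from compound 1 to compound 3 (0.66 log units; beyond the scatter) and a 12-fold lower number from compound 2 to compound 3 (1.09 log units; beyond the scatter). Between the other two, a 2.7-fold higher number from compound 1 to compound 2 (0.43 log units; beyond the scatter).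

Compound 4 `CC(C)c1cccc(C(C)C)c1OC(=O)NC(=O)OCCCc1ccccc1` is the next compound of interest. Its difference from compound 3 is phenethyl in place of phenyl on a saturated chain carbon bound to an oxygen next to a carbonyl group. The measured steps all concern what sits on the saturated chain carbon bound to an aromatic carbon and an oxygen next to a carbonyl group, where hydrogen gave the lowest number and bulkier groups gave higher numbers. Going by the values given here, the change to compound 4 leaves that carbon carrying hydrogen and instead lengthens the chain between the oxygen and the ring, so none of the measured steps speaks to it directly. Among the compounds with values here, with no direct precedent, the account expects only a small shift in this assay, if any, leaning toward a somewhat higher number: a 1.7-fold higher number from compound 3 to compound 4 (0.23 log units; within the scatter). Compound 4 is therefore estimated at 130 nM, with a range from 40 nM to 450 nM.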

Compound 4, half-maximal inhibitory concentration: 660 nM
Compound 4: middle estimate off by 5.1-fold (0.71 log units), on the low side; measured number above the stated range.
By their numbers in this assay, from the lowest: compound 3; then compounds 1, 4 and 2 (each within the scatter of the next, the first and the last beyond it).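

Lengthening benzyl to 3-phenylpropyl, with the carbon bound to the oxygen next to a carbonyl group still carrying only hydrogen, gives an 8.6-fold higher number from compound 3 to compound 4 (0.93 log units; beyond the scatter) in this assay, so this part of the molecule also responds to change, which the earlier steps could not show because they concerned only what sits on that carbon. Compound 3 remains the lowest of the four on this read-out, with its steps to the other three all beyond the scatter, so the benzyl group is the best of the groups seen here, whether the change adds a substituent to the chain carbon or lengthens the chain. Nothing available here explains why the longer chain gives the higher number.

The compounds shown leave open how the number moves with chain length, since a 2-phenylethyl group would show whether the rise sets in gradually or only at the 3-phenylpropyl group, and a 4-phenylbutyl group would show whether it continues. They also leave open whether the aromatic ring is needed at the end of the chain at all, a question that a plain hexyl chain, or a carboxylic acid or an amine on the ring of the benzyl group, would begin to address.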